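A few compounds are considered here, and "the series" means these few. Any claim that something is new, unique, unknown or untested is made for them only; others in the source may bear on it.

Compound 1 `CCOC(=O)Cn1ncc2c(Nc3ccc(NC(=O)CCl)cc3)ncnc21`: 3.51 ug/mL
Compound 2 `O=C(O)Cn1ncc2c(Nc3ccc(NS(=O)(=O)c4ccc([N+](=O)[O-])cc4)cc3)ncnc21`: > 100 ug/mL (a limit)
Compound 3 `CC(=O)Nc1ccc(Nc2ncnc3c2cnn3CC(=O)O)cc1`: > 64 ug/mL (a limit)

Going by the values given here, in a functional assay on cells (Homo sapiens) for inhibition, read by MTT assay, with a stated time of 72 h (a lower number here means a stronger inhibitor, a higher number a weaker inhibitor), compound 1 gives 3.51 ug/mL, the only actual number among the three compounds tested. Compound 2 reaches only a limit, > 100 ug/mL. Compound 3 also reaches only a limit, > 64 ug/mL. Among the compounds with values here, compound 1 therefore stands alone as the one compound with a measured potency, and the other two offer no number to set beside it. Within the data shown here, no pair of the three differs in just one place, so the data hold no measured single change to serve as a guide.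

The next compound, compound 4 `CCOC(=O)Cn1ncc2c(Nc3ccc(N)cc3)ncnc21`, has not yet been measured in this assay. It carries hydrogen in place of (chloromethyl)carbonyl on a nitrogen on an aromatic ring, and the rest of the core of compound 1 stays the same: hydrogen in place of (chloromethyl)carbonyl on a nitrogen on an aromatic ring. Among the measured compounds shown here, compound 1 at 3.51 ug/mL is the only compound with a number, so a loss of strength seems likelier than a gain, although the size of any loss is uncertain. The expected change is a 4.0-fold higher number from compound 1 to compound 4 (0.60 log units; beyond the scatter), a moderate weakening beyond the scatter. For compound 4 the estimated value is 14 ug/mL, with an expected range of 4 ug/mL to 60 ug/mL.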

Compound 4, half-maximal inhibitory concentration: > 64 ug/mL
Compound 4: only a limit was reported; the forecaster's own chance of this, stated with the estimate: 20%; middle value at least 4.5-fold (0.66 log units) away from the limit.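

Going by these compounds alone, the step gives the first measured single change in this set: in this assay, hydrogen in place of (chloromethyl)carbonyl on a nitrogen on an aromatic ring produces an at least 18-fold higher number from compound 1 to compound 4 (1.26 log units; beyond the scatter). The measurable strength of compound 1 in this assay therefore depends on the ((chloromethyl)carbonyl)amino group at this place, since the rest of the core of compound 1 stays the same in compound 4 and the free amino group leaves no measured number. The reading for compound 4, > 64 ug/mL, is a limit and not a number, so the step gives only a lower bound on the change, and compound 4 sits with the other compound that stops at this limit: the limit of > 64 ug/mL in this assay, at which 2 of the 4 values shown sit.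

The compounds shown leave open whether the chlorine matters or the acylated nitrogen alone, a question that a propanoyl or a bromoacetyl group on this nitrogen, with the rest of compound 1 kept, would address. Within the data shown here, they also leave open what the ethyl ester contributes, as no pair differs there alone, and a methyl ester or a primary amide in its place would test that.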